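Amide to Urea Exchange on a Pyrazole Scaffold

The source may hold more compounds than are shown below. What is called first, only, known or untested is meant among the compounds shown, and "the series" means these compounds.

Measured compounds:
compound 1, `COc1cc(-c2nn(-c3cccc(NC(=O)c4ccc(Cl)c(C(F)(F)F)c4)c3)cc2-c2ccncc2)ccc1Cl`: > 32500 nM
compound 2, `O=C(Nc1cccc(-n2cc(-c3ccncc3)c(-c3ccc(Cl)c(O)c3)n2)c1)Nc1ccc(Cl)c(C(F)(F)F)c1`: > 32500 nM

Compound 1 was tested in a functional assay on RXF 393 cells (Homo sapiens) for inhibition, read by sulforhodamine B assay, with a stated time of 48 h; on this read-out higher numbers stand for lower toxicity in this test and lower numbers for higher toxicity in this test. Compound 1 gives > 32500 nM, which is a limit of the assay rather than a number. Compound 2 likewise gives > 32500 nM in this assay, again only a limit. For the measured compounds named here, compound 1 therefore stands at the limit, as does the one other value shown, so no order between the two can be stated.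

The unmeasured compound 3, `COc1cc(-c2nn(-c3cccc(NC(=O)Nc4ccc(Cl)c(Cl)c4)c3)cc2-c2ccncc2)ccc1Cl`, differs from compound 1 in one place: (3,4-dichlorophenyl)amino in place of 4-chloro-3-(trifluoromethyl)phenyl on a carbonyl carbon.

Going by the values given here, no step between measured compounds is available. Because the limit of > 32500 nM in this assay, at which 2 of the 2 values shown sit, gathers both measured values at the same limit, the step from compound 1 to compound 3 is expected to be a step that the limit leaves unreadable from compound 1 to compound 3, that is nothing beyond the scatter, with the result most likely again a limit. Compound 3 is expected to give about 40000 nM in this assay, within a range of 15000 nM to 100000 nM.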

Compound 3, concentration lethal to 50% of the cells: > 50000 nM
Compound 3: no number, only a limit (the forecaster's own chance of this, stated with the estimate: 80%); middle value at least 1.2-fold (0.09 log units) away from the limit.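

In this assay, compound 3 gives > 50000 nM, again a limit of the assay and not a number. For the compounds shown here, compound 1 also stands at a limit, so no step from compound 1 to compound 3 can be read. The compounds shown leave open what (3,4-dichlorophenyl)amino in place of 4-chloro-3-(trifluoromethyl)phenyl does to the value in this assay.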